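The source may hold more compounds than are shown below. What is called first, only, known or untested is meant among the compounds shown, and "the series" means these compounds.

Working notes on the series. Compound 1 `CCn1c(/C=C2/C(=O)Nc3ccccc32)nc2ccccc21`, compound 2 `CC(C)n1c(/C=C2/C(=O)Nc3ccccc32)nc2ccccc21` and compound 3 `CCn1c(/C=C2/C(=O)Nc3ccc(Br)cc32)nc2ccccc21` have been measured; compound 4 `Cn1c(/C=C2/C(=O)Nc3ccc(Br)cc32)nc2ccccc21` has not. In a functional assay on PC-3 cells (Homo sapiens) for cytotoxicity, read by MTT assay, with a stated time of 48 h (on this read-out lower numbers stand for stronger inhibition and higher numbers for weaker inhibition), compound 1 gives 38000 nM, compound 2 gives 37600 nM and compound 3 gives 42700 nM. The change hydrogen in place of methyl on a saturated chain carbon bound to an aromatic nitrogen and a saturated chain carbon gives a 1.0-fold higher number from compound 2 to compound 1 (0.00 log units; within the scatter). Bromo in place of hydrogen on an aromatic carbon gives a 1.1-fold higher number from compound 1 to compound 3 (0.05 log units; within the scatter). The difference between the core of compound 2 and the core of compound 3 is not broken down here. Compound 4 differs from compound 3 by hydrogen in place of methyl on a saturated chain carbon bound to an aromatic nitrogen; its place lacks the saturated chain carbon present at the place of the earlier change, so this is the same kind of change, not the same. Resting on a 1.0-fold higher number from compound 2 to compound 1 (0.00 log units; within the scatter), compound 4 is expected to show a 1.0-fold lower number from compound 3 to compound 4 (0.01 log units; within the scatter) in this assay. Compound 4 is estimated at 42000 nM, with a range from 21000 nM to 84000 nM.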

Compound 4, half-maximal inhibitory concentration: > 50000 nM
Compound 4 gave a limit, no number; the forecaster's own chance of this, stated with the estimate: 10%; at least 1.1-fold (0.07 log units) between middle value and limit.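

In this assay compound 4 gives > 50000 nM and this is a limit of the assay, not a number. The new step therefore stands only as a floor of an at least 1.1-fold higher number from compound 3 to compound 4 (0.06 log units; that floor lies within the scatter) and does not show whether this change carries from one core to another in the same size: the same change on two cores in this assay, a 1.0-fold higher number (0.00 log units; within the scatter) from compound 2 to compound 1 and an at least 1.1-fold higher number (0.06 log units; that floor lies within the scatter) from compound 3 to compound 4; the limit leaves it open whether they differ
The reading also stops at the limit of the assay: the limit of > 50000 nM in this assay, at which 1 of the 4 values shown sits.
Open, from the compounds shown here alone, is how a longer chain, or a chain ending in an amine or a carboxylic acid, would read in this assay at this place. Also open, going by these compounds, is whether a group other than bromo, such as methoxy or a carboxylic acid, would give a number apart from the others on these cores.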